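Cyclopentyl for propyl in the antiproliferative series

This account rests on a few compounds, and the source may have more. Where it says the series, first, only, none or still open, it means among the compounds named here.

Measured in a functional assay on K562 cells (Homo sapiens) for inhibition, read by trypan blue exclusion, with a stated time of 72 h; a lower number here means a stronger inhibitor, a higher number a weaker inhibitor:
- compound 1 `COC(=O)Cn1c(=O)c(S(=O)(=O)c2ccc(F)cc2F)cc2cnc(Nc3ccc4[nH]ccc4c3)nc21`: 5000 nM
- compound 2 `Cn1c(=O)c(C(=O)Nc2ccc(F)cc2F)cc2cnc(Nc3ccc4[nH]ccc4c3)nc21`: 5000 nM
- compound 3 `CCCn1c(=O)c(S(=O)(=O)c2ccc(F)cc2F)cc2cnc(Nc3ccc4[nH]ccc4c3)nc21`: 1000 nM

Compound 3 gives the lowest number of the three at 1000 nM and lies beyond the scatter from both others. Compound 4 `O=c1c(S(=O)(=O)c2ccc(F)cc2F)cc2cnc(Nc3ccc4[nH]ccc4c3)nc2n1C1CCCC1` keeps the rest of compound 3 and carries cyclopentyl in place of propyl on an aromatic nitrogen. Among the compounds with values here, one measured step bears on this change, since it alters the group on the same nitrogen: a 5.0-fold lower number from compound 1 to compound 3 (0.70 log units; beyond the scatter). That step is modest but beyond the scatter. Compound 2 differs from compound 3 in more than one place, so it gives no clean comparison. Within the data shown here, no measured compound has a ring on this nitrogen, so the direction rests on thin evidence. A modest further fall in this assay is expected, with the estimate being a 2.5-fold lower number from compound 3 to compound 4 (0.40 log units; beyond the scatter). The estimate for compound 4 is 400 nM, with an expected range from 80 nM to 2000 nM.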

Compound 4, half-maximal inhibitory concentration: 5000 nM
Beside the measured number, compound 4's estimate is 13-fold (1.10 log units) below it; measured number above the stated range.
By their numbers in this assay, from the lowest: compound 3; then compounds 1, 2 and 4 (each within the scatter of the next).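

In this assay the change from propyl to cyclopentyl gives a 5.0-fold higher number from compound 3 to compound 4 (0.70 log units; beyond the scatter) and so runs opposite to the earlier step on this nitrogen: a group of carbon only does not by itself carry the lower number seen with propyl. The ring and the (methoxycarbonyl)methyl group also read alike, with no change at the digits printed from compound 1 to compound 4 (within the scatter), so these two dissimilar groups cannot be told apart in this assay, and propyl alone stands apart from them. Nothing measured accounts for the loss on going to the ring.

Going by these compounds, whether the lower number depends on an open chain, on its length, or on the absence of branching remains open. Within the data shown here, an isopropyl group, a butyl chain or a cyclopropyl ring on this nitrogen would separate these readings, and the single propyl value cannot do so.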